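The source may report more compounds than this note shows. Statements on the series, on what has been measured and on what is new or still open speak of the compounds shown alone.

Compound 1 `C[C@H](NC(=O)CN(c1nc(Cl)nc2[nH]cnc12)C1CC1)C(=O)OCc1ccccc1` gives the highest of the three numbers in a functional assay on the whole organism (Tail, strain ICR) with Mus musculus as the target, in the tail flick test, with a stated time of 90 min, at a dose of 25 umol/kg by the oral route (a higher number here means a stronger effect of the compound at the dose given, a lower number a weaker effect), with a value of 44.2%. Compound 2 `O=C(CN(c1ncnc2c1ncn2C1CCCCO1)C1CC1)NCC(=O)OCc1ccccc1` reaches 25.9% in this assay, and compound 3 `O=C(O)C[C@H](NC(=O)CN(c1nc(Cl)nc2[nH]cnc12)C1CC1)C(=O)O` reaches 25.1% in this assay; both gaps to compound 1 lie beyond the scatter. Compound 4 `NC(=O)CC[C@H](NC(=O)CN(c1nc(Cl)nc2[nH]cnc12)C1CC1)C(=O)OCc1ccccc1` has not been measured. It differs from compound 1 by carbamoylmethyl in place of hydrogen on a saturated chain carbon, two bonds along the chain from an amide-type nitrogen and a carbonyl carbon. Going by the values given here, no measured pair shows this change by itself, so nothing measured tells how large its effect is. Compound 4 is expected to sit somewhat below compound 1, a step of a number 9.2 percentage points lower from compound 1 to compound 4 (within the scatter) that could still stay within the scatter. The estimate for compound 4 in this assay is 35%, with a range from 15% to 55%.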

Compound 4, a percentage reported as activity, at one dose (the size of the read-out at that dose, not a potency): 42.8%
The estimate for compound 4 lay 7.8 percentage points below the measured number, and the stated range covers the measured number.
By their numbers in this assay, from the lowest: compounds 3 and 2 (each within the scatter of the next); then compounds 4 and 1 (each within the scatter of the next).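

In this assay, carbamoylmethyl in place of hydrogen on this saturated chain carbon gives a number 1.4 percentage points lower from compound 1 to compound 4 (within the scatter) and thus no change that can be told from the scatter. Going by these compounds alone, this is the first reading at this position, and it shows that the larger group can stand here without a clear loss of effect at the dose given. Nothing measured here offers a reason for this result. Going by these compounds, whether an amine or a longer chain at this carbon would behave in the same way remains open, and so does whether compound 1 and compound 4 would also match at other doses.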